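From Two Methoxy Groups to Three

The compounds below may be only part of what the source reports. "The series", "measured", "known", "first", "only" and "open" are said of these compounds alone.

Of the compounds shown here, three sharing one core have been tested in a functional assay on HL-60 cells (Homo sapiens) for cytotoxicity, read by MTT assay, with a stated time of 24 h; on this read-out lower numbers stand for stronger inhibition and higher numbers for weaker inhibition. Compound 1 `COC(=O)/C(=C\c1ccc(OC(=O)c2cccc(OC)c2)cc1)Sc1ccnc2cc(Cl)ccc12` gives 25500 nM. Compound 2 `COC(=O)/C(=C\c1ccc(OC(=O)c2ccc(OC)cc2OC)cc1)Sc1ccnc2cc(Cl)ccc12` gives 7640 nM, and compound 3 `COC(=O)/C(=C\c1ccc(OC(=O)c2cccc(OC)c2OC)cc1)Sc1ccnc2cc(Cl)ccc12` gives 13000 nM. The number for compound 3 is the second highest of the three: there is a 1.7-fold higher number from compound 2 to compound 3 (0.23 log units; within the scatter), and there is a 2.0-fold lower number from compound 1 to compound 3 (0.29 log units; within the scatter), so compound 3 cannot be separated from either neighbour on this read-out.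

Compound 4 `COC(=O)/C(=C\c1ccc(OC(=O)c2cc(OC)c(OC)cc2OC)cc1)Sc1ccnc2cc(Cl)ccc12` has not yet been measured. It differs from compound 3 in one place: 2,4,5-trimethoxyphenyl in place of 2,3-dimethoxyphenyl on a carbonyl carbon. For the measured compounds named here, two measured steps bear on this change. Going by the values given here, the first is a 3.3-fold lower number from compound 1 to compound 2 (0.52 log units; beyond the scatter), the only step in the set that exceeds the scatter; the second is a 1.7-fold higher number from compound 2 to compound 3 (0.23 log units; within the scatter). Compound 4 carries the two methoxy groups found in compound 2, which gave 7640 nM, together with a third methoxy group for which no measurement exists. A lower number than that of compound 3 is therefore expected, of roughly the size seen between compound 1 and compound 2, with the third methoxy group treated as neutral. The expected step is a 1.6-fold lower number from compound 3 to compound 4 (0.21 log units; within the scatter). Compound 4 is estimated at 8000 nM, with a range from 3000 nM to 20000 nM.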

Compound 4, half-maximal inhibitory concentration: 6260 nM
Compound 4: the middle estimate sits 1.3-fold (0.11 log units) above what was measured, within the range that was stated.
By their numbers in this assay, from the lowest: compounds 4, 2, 3 and 1 (each within the scatter of the next, the first and the last beyond it).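

For the compounds shown here, exchanging 2,3-dimethoxyphenyl for 2,4,5-trimethoxyphenyl on the carbonyl carbon gives a 2.1-fold lower number from compound 3 to compound 4 (0.32 log units; beyond the scatter), the first change between two dimethoxy-or-richer groups at this position that stands clear of the scatter. Measured against the 3-methoxyphenyl group, the 2,4,5-trimethoxyphenyl group gives a 4.1-fold lower number from compound 1 to compound 4 (0.61 log units; beyond the scatter), the largest step in the set, though still a modest one. A methoxy in place of hydrogen on an aromatic carbon gives only a 1.2-fold lower number from compound 2 to compound 4 (0.09 log units; within the scatter), so the third methoxy group adds nothing that can be read here, and this change behaves alike in both places it occurs: the same change on two cores in this assay, a 2.0-fold lower number (0.29 log units; within the scatter) from compound 1 to compound 3 and a 1.2-fold lower number (0.09 log units; within the scatter) from compound 2 to compound 4, 1.6-fold (0.21 log units) apart, within the scatter of two such steps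

As far as these compounds go, every group on this carbonyl carbon is a methoxy-bearing phenyl, so it remains open whether the trend toward lower numbers depends on methoxy itself or would also appear with an ethoxy group, a hydroxyl group or an amine on the same ring. It also remains open how far the arrangement of the methoxy groups matters on its own, as the compounds shown vary their number and their places together.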